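Compound 2 to Compound 4: Anilino Replaces 3-Chlorobenzyl

The source may hold more compounds than are shown below. What is called first, only, known or untested is meant among the compounds shown, and "the series" means these compounds.

The series was tested in an in vitro assay on CHOk1 cells with adenosine receptor A1 (Homo sapiens) as the target; a lower number here means that less compound is needed, a higher number that more compound is needed for the effect. Compound 1 `Nc1sc2c(c1C(=O)O)CCN(Cc1ccccc1)C2` gives 8000 nM. Compound 2 `Nc1sc2c(c1C(=O)NCc1cccc(Cl)c1)CCN(Cc1ccccc1)C2` reaches only the assay limit, > 20000 nM, so no number is known for it. That step, an at least 2.5-fold higher number from compound 1 to compound 2 (0.39 log units; beyond the scatter), is the largest seen here. Compound 3 `Nc1sc2c(c1C(=O)NCc1cccc(C(F)(F)F)c1)CCN(Cc1ccccc1)C2` gives 15500 nM, and the step of an at least 1.2-fold lower number from compound 2 to compound 3 (0.11 log units; that floor lies within the scatter) stays within the scatter at its floor. Compound 2 therefore stands at the limit of > 20000 nM in this assay, at which 1 of the 3 values shown sits, with only a limit and no value to anchor it.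

Compound 4 `Nc1sc2c(c1C(=O)NNc1ccccc1)CCN(Cc1ccccc1)C2` differs from compound 2 by anilino in place of 3-chlorobenzyl on an amide-type nitrogen. Going by the values given here, two measured steps bear on this change: the step from compound 1 to compound 2 showed that an amide on the carbonyl carbon raised the number, and the step from compound 2 to compound 3 showed that altering the group on that amide nitrogen moved the number no further than the scatter. The anilino amide is therefore expected to sit near compound 2, with no step beyond the scatter in this assay. Compound 4 is expected to give about 20000 nM, within 6000 nM to 60000 nM. That estimate amounts to a number no higher from compound 2 to compound 4 (the limit leaves the size open).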

Compound 4, half-maximal effective concentration: 7800 nM
Estimate against measurement, compound 4: 2.6-fold (0.41 log units) above, and the stated range covers the measured number.
By their numbers in this assay, from the lowest: compounds 4, 1 and 3 (each within the scatter of the next). At a limit, above all of these: compound 2.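

The result shows that, in this assay, the group on the amide-type nitrogen can move the number beyond the scatter: anilino in place of 3-chlorobenzyl gives an at least 2.5-fold lower number from compound 2 to compound 4 (0.40 log units; beyond the scatter). It also shows that replacing the hydroxy on the carbonyl carbon does not by itself raise the number, since anilinoamino in its place gives a 1.0-fold lower number from compound 1 to compound 4 (0.01 log units; within the scatter). Compound 2 remains a limit and not a number, so the full size of its step to compound 4 stays open: the limit of > 20000 nM in this assay, at which 1 of the 4 values shown sits.

The compounds shown leave open whether the change in number follows from the nitrogen that anilino brings or from the loss of the chloro group, a question that an unsubstituted benzyl on the same nitrogen would address. Also open, from the compounds shown here alone, is how a chloro-substituted anilino, or a simple methylamino on the carbonyl carbon, would read in this assay.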